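The source may report more compounds than this note shows. Statements on the series, on what has been measured and on what is new or still open speak of the compounds shown alone.

Working notes on the series.

Of the compounds shown here, two have been measured so far in a functional assay on A549 cells (Homo sapiens) for cytotoxicity, read by MTT assay, with a stated time of 72 h; a lower number here means a stronger inhibitor, a higher number a weaker inhibitor. Compound 1 `COc1cc2c(Oc3ccc(NC(=O)c4cn(-c5ccc(F)c(F)c5)nn4)cc3F)ccnc2cc1OCCCN1CCCCC1` gives 220 nM in this assay. Compound 2 `COc1cc2c(Oc3ccc(NC(=O)c4cn(-c5c(C)cccc5C)nn4)cc3F)ccnc2cc1OCCCN1CCC(C)CC1` gives 3340 nM in this assay, which is the higher of the two numbers, and the gap to compound 1 is beyond the scatter. The two compounds differ in more than one place, so no single step can be read from that pair; only what the two values show is stated here.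

Compound 3 `COc1cc2c(Oc3ccc(NC(=O)c4cn(-c5ccc(F)c(F)c5)nn4)cc3F)ccnc2cc1OCCCN1CCC(C)CC1` is not yet measured. It derives from compound 2 by one change: 3,4-difluorophenyl in place of 2,6-dimethylphenyl on an aromatic nitrogen. The group that enters is the same one that compound 1 carries at that position, and compound 1 differs from compound 3 only elsewhere in the molecule.

Among the compounds with values here, no measured step covers this change, so the expectation rests on the pair above. Given that compound 1, carrying the 3,4-difluorophenyl group, gives 220 nM, a step downward from compound 2 to compound 3 of about an 8.4-fold lower number from compound 2 to compound 3 (0.92 log units; beyond the scatter) is expected, beyond the scatter. For compound 3 in this assay the estimate is 400 nM, with a range from 120 nM to 1500 nM.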

Compound 3, half-maximal inhibitory concentration: 1460 nM
Beside the measured number, compound 3's estimate is 3.7-fold (0.56 log units) below it, and the stated range covers the measured number.
By their numbers in this assay, from the lowest: compound 1; then compound 3; then compound 2.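

Compound 3 separates the two places at which compound 1 and compound 2 differ. In this assay, 3,4-difluorophenyl in place of 2,6-dimethylphenyl on the aromatic nitrogen, with the rest of the molecule held constant, gives a 2.3-fold lower number from compound 2 to compound 3 (0.36 log units; beyond the scatter), so the group at this position matters, though the step is modest; methyl in place of hydrogen on a saturated ring carbon, read separately, gives a 6.6-fold higher number from compound 1 to compound 3 (0.82 log units; beyond the scatter), a step also beyond the scatter and larger in size than the step at the aromatic nitrogen. Nothing available here bears on the origin of either step.

These compounds leave open how much of the aryl step belongs to the two fluorines and how much to the loss of the two methyl groups, and an unsubstituted phenyl or a pyridyl ring on the same nitrogen would bear on that. On these data alone, it also remains open whether the rise with methyl on the saturated ring carbon extends to a larger group there, such as ethyl, or to a hydroxyl group, and whether the size of either step holds when the group at the other place is changed.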